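The compounds below may be only part of what the source reports. "The series", "measured", "known", "first", "only" and "open" are said of these compounds alone.

Compounds measured in a functional assay on MT4 cells (Homo sapiens) for inhibition; a lower number here means a stronger inhibitor, a higher number a weaker inhibitor:
Compound 1, `C/C(=C\COC(=O)Nc1ccccc1)C1=CC(=O)C(C)(C)O1`: 103 ug/mL
Compound 2, `C/C(=C\COC(=O)NC(C)C)C1=CC(=O)C(C)(C)O1`: 2.3 ug/mL

Among the measured compounds shown here, compound 2 stands lowest of the two numbers so far; its nearest neighbour is compound 1, and the one known step, a 45-fold lower number from compound 1 to compound 2 (1.65 log units; beyond the scatter), separates them. That step is the whole body of evidence on the amide-type nitrogen in this series.

Compound 3, `C/C(=C\COC(=O)NC1CCCCC1)C1=CC(=O)C(C)(C)O1`, has not yet been measured. It differs from compound 2 in one place: cyclohexyl in place of isopropyl on an amide-type nitrogen. For the measured compounds named here, no measured pair reports this exact exchange. The step of a 45-fold lower number from compound 1 to compound 2 (1.65 log units; beyond the scatter) bears on it only loosely: it shows that replacing an aromatic ring by a small branched alkyl on that nitrogen moved the number a long way, but the present change keeps an alkyl group and merely enlarges it to a saturated ring. On that basis no clear direction can be argued for compound 3, and a step within or close to the scatter in this assay is the expectation, expressed as a 1.1-fold higher number from compound 2 to compound 3 (0.04 log units; within the scatter). Compound 3 is therefore estimated at 2.5 ug/mL, with a plausible range from 0.8 ug/mL to 8 ug/mL.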

Compound 3, half-maximal inhibitory concentration: 2.4 ug/mL
For compound 3 the middle estimate is 1.0-fold (0.02 log units) above the measured one, and the stated range covers the measured number.
By their numbers in this assay, from the lowest: compounds 2 and 3 (each within the scatter of the next); then compound 1.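

In this assay, the exchange of isopropyl for cyclohexyl on the amide-type nitrogen gives a 1.0-fold higher number from compound 2 to compound 3 (0.02 log units; within the scatter), so at this place a saturated ring with more carbon atoms reads the same as the small branched alkyl. The other step, a 43-fold lower number from compound 1 to compound 3 (1.63 log units; beyond the scatter), shows that the wide gap to phenyl is not confined to isopropyl: two different non-aromatic carbon groups now stand far from compound 1, and none of the compounds shown goes against this. Nothing at hand explains why phenyl parts so widely from these two alkyl groups, or why isopropyl and cyclohexyl do not part at all.

Going by these compounds, it remains open whether the same reading would hold for a smaller group such as methyl, a straight chain such as n-butyl, or benzyl, which would show whether the gap follows an aromatic ring at any distance. Nor do the compounds shown tell how a cyclohexyl carrying a hydroxyl or an amine would read, or whether any of this carries over to a change in the shared core.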